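Isopentyl for Phenyl: Expected Tolerance on Liver Cells

The source may report more compounds than this note shows. Statements on the series, on what has been measured and on what is new or still open speak of the compounds shown alone.

Compound 1, `CC(C)CCn1nc(-c2cccs2)c(O)c(C2=NS(=O)(=O)c3cc(S(=O)(=O)N(C)C)ccc3N2)c1=O`: in an ADME assay on Huh-7 cells (Homo sapiens) for cytotoxicity, with a stated time of 72 h (a higher number here means that more compound is tolerated, a lower number that less compound is tolerated), compound 1 has "not determined" (no result reported).
Compound 2, `CS(=O)(=O)Nc1ccc2c(c1)S(=O)(=O)N=C(c1c(O)c(-c3ccc(Cl)s3)nn(CCC3CC3)c1=O)N2`: in this assay compound 2 gives > 33000 nM, which is a limit of the assay and not a number.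
Compound 3, `CC(C)CCn1nc(-c2ccccc2)c(O)c(C2=NS(=O)(=O)c3cc(NS(C)(=O)=O)ccc3N2)c1=O`: in this assay compound 3 gives > 1000 nM, again a limit and not a number.

Compound 3 therefore stands without a single number in this assay: its result is a limit, the result for compound 2 is also a limit, and compound 1 has no result at all. Within the data shown here, with two limits and one blank, no step between measured compounds can be drawn, so nothing in these data shows how a change of structure moves the read-out here.

Compound 4, `CC(C)CCc1nn(CCC(C)C)c(=O)c(C2=NS(=O)(=O)c3cc(NS(C)(=O)=O)ccc3N2)c1O`, differs from compound 3 in one place: isopentyl in place of phenyl on an aromatic carbon. Nothing measured points either way. The step from compound 3 to compound 4 is expected to stay within the scatter, as a step that the limit leaves unreadable from compound 3 to compound 4. Compound 4 is expected to give about 20000 nM, estimated to lie between 3000 nM and 100000 nM, most likely again reported as a limit.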

Compound 4, half-maximal cytotoxic concentration: > 33000 nM
Compound 4 ended at the assay's limit; the forecaster's own chance of this, stated with the estimate: 70%; middle value at least 1.6-fold (0.21 log units) away from the limit.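

No step can be read between compound 3 and compound 4 in this assay, as the result for each is a limit and not a number. The compounds shown leave open whether putting isopentyl in place of phenyl changes the tolerated concentration at all.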